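A Methyl for a Hydrogen in Compound 4

The compounds below may be only part of what the source reports. "The series", "measured", "known", "first", "only" and "open" are said of these compounds alone.

Compound 1 `Oc1ccc([C@@H]2C/C(=N\Nc3ccc(Br)cn3)c3c(O)cc(O)cc3O2)cc1`: >= 11300 nM
Compound 2 `O=C(N/N=C1\C[C@@H](c2ccc(O)cc2)Oc2cc(O)cc(O)c21)c1cccs1`: >= 11300 nM
Compound 3 `O=C(N/N=C1\C[C@@H](c2ccc(O)cc2)Oc2cc(O)cc(O)c21)OCc1ccccc1`: >= 11300 nM

The three compounds were tested in a functional assay on L5178Y cells (Mus musculus) for inhibition, read by MTT assay, with a stated time of 24 h; on this read-out lower numbers stand for stronger inhibition and higher numbers for weaker inhibition. For compound 1 the value >= 11300 nM is a limit of the assay, not a number. For compound 2 the value >= 11300 nM is likewise a limit. For compound 3 the value >= 11300 nM is also a limit. All three sit at the limit of >= 11300 nM in this assay, at which 3 of the 3 values shown sit, so the steps a step that the two limits leave unreadable from compound 1 to compound 2, a step that the two limits leave unreadable from compound 1 to compound 3 and a step that the two limits leave unreadable from compound 2 to compound 3 cannot be read. Compound 4 `COc1cc(O)c2c(c1)O[C@H](c1ccc(O)cc1)C/C2=N\NC(=O)c1cccs1` differs from compound 2 by methyl in place of hydrogen on an oxygen on an aromatic ring. Going by the values given here, no measured step touches an oxygen on an aromatic ring, so none bears directly on this change; the only guidance is that every measured value is a limit. Compound 4 is therefore expected to stay near the limit, a step that the limit leaves unreadable from compound 2 to compound 4. The estimate for compound 4 is 15000 nM, within 5000 nM to 60000 nM.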

Compound 4, half-maximal inhibitory concentration: 9400 nM
Beside the measured number, compound 4's estimate is 1.6-fold (0.20 log units) above it, and the stated range covers the measured number.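

Among the compounds shown, only compound 4 carries a number rather than a limit, and the others sit at one limit: the limit of >= 11300 nM in this assay, at which 3 of the 4 values shown sit. In this assay, methyl in place of hydrogen on this oxygen gives an at least 1.2-fold lower number from compound 2 to compound 4 (0.07 log units; that floor lies within the scatter). Going by these compounds, the change is thus the first here to yield a readable value, though the floor of the step does not exceed the scatter and the true size stays unknown.

On these data alone, whether a longer chain such as ethyl on this oxygen would move the number further remains open. So does whether methyl here would act alike with the groups carried by compound 1 and compound 3.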